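Replacing the silicon-bearing group of compound 3 with methoxymethoxy

The compounds below may be only part of what the source reports. "The series", "measured", "known", "first", "only" and "open" are said of these compounds alone.

Within the data shown here, in a functional assay on HL-60 cells (Homo sapiens) for antiproliferative activity, read by MTT assay, with a stated time of 48 h (on this read-out higher numbers stand for weaker inhibition and lower numbers for stronger inhibition), compound 3 (`CC[Si](CC)(CC)C/C1=C/C[C@](C)(CCC=C(C)C)/C=C/[C@@H](OC(=O)C=C(C)C)[C@](C)(O)/C=C/C1=O`) gives 2810 nM, the highest of the three numbers measured so far. On the same core, compound 1 (`CC(C)=CCC[C@]1(C)/C=C/[C@@H](OC(=O)C=C(C)C)[C@](C)(O)/C=C/C(=O)/C(CN(C)C)=C\C1`) gives 140 nM and compound 2 (`CCN(CC)C/C1=C/C[C@](C)(CCC=C(C)C)/C=C/[C@@H](OC(=O)C=C(C)C)[C@](C)(O)/C=C/C1=O`) gives 140 nM.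

Compound 4 (`COCOC/C1=C/C[C@](C)(CCC=C(C)C)/C=C/[C@@H](OC(=O)C=C(C)C)[C@](C)(O)/C=C/C1=O`) is still unmeasured and differs from compound 3 at the same place: a group of 4 heavy atoms (2 carbon, 2 oxygen; no ring) in place of a group of 7 heavy atoms (6 carbon, 1 silicon; no ring), on a saturated chain carbon bound to a double-bonded ring carbon. Neither the entering nor the leaving group carries a net charge.

All three measured steps bear on this place. Exchanging dimethylamino for diethylamino shows no change at the digits printed from compound 1 to compound 2 (within the scatter). The large steps are those to the silicon-bearing group: a 20-fold higher number from compound 1 to compound 3 (1.30 log units; beyond the scatter) and a 20-fold higher number from compound 2 to compound 3 (1.30 log units; beyond the scatter). Across these compounds, both nitrogen-bearing groups sit at the low number and the silicon-bearing group at the high one, with no exception among the three.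

Methoxymethoxy contains neither nitrogen nor silicon, so no measured step covers it directly. It is a smaller group than the one leaving, so a partial return towards compound 1 is expected, and the uncertainty is wide. The expected change is a 4.0-fold lower number from compound 3 to compound 4 (0.60 log units; beyond the scatter), a lower number but not a full recovery. For compound 4 the estimated value is 700 nM, with an expected range from 200 nM to 2500 nM.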

Compound 4, half-maximal inhibitory concentration: 2840 nM
The estimate for compound 4 lay 4.1-fold (0.61 log units) below the measured number, outside the stated range (above it).
By their numbers in this assay, from the lowest: compounds 1 and 2 (each within the scatter of the next); then compounds 3 and 4 (each within the scatter of the next).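

In this assay, methoxymethoxy in place of the silicon-bearing group gives a 1.0-fold higher number from compound 3 to compound 4 (0.00 log units; within the scatter), so two nitrogen-free groups that differ in heavy-atom count and in hydrogen-bond acceptors read alike at this place. Methoxymethoxy also stands apart from both amines, with a 20-fold higher number from compound 1 to compound 4 (1.31 log units; beyond the scatter) and a 20-fold higher number from compound 2 to compound 4 (1.31 log units; beyond the scatter); the high number therefore does not depend on silicon, and across these four compounds both nitrogen-bearing groups sit at the low numbers and both nitrogen-free groups at the high numbers, without exception. No measurement at hand explains this split.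

From the compounds shown here alone, the link to nitrogen rests on dimethylamino and diethylamino alone, so it remains open whether any nitrogen on this saturated chain carbon gives the low number or only an open-chain amine of this kind. A piperidine would test a ring amine, acetamido a nitrogen in an amide and a plain hydroxyl a small oxygen group, while a carboxylic acid would show how a further group without nitrogen reads in this assay.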